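A few compounds are considered here, and "the series" means these few. Any claim that something is new, unique, unknown or untested is made for them only; others in the source may bear on it.

Series notes. Compound 1 `CCS(=O)(=O)Nc1cc(-c2ccc3ncnc(Nc4ccc(OC)cc4)c3c2)cnc1OC` is the reference point: in a functional assay on MCF7 cells (Homo sapiens) for cytotoxicity, read by sulforhodamine B assay, with a stated time of 72 h (on this read-out lower numbers stand for stronger inhibition and higher numbers for weaker inhibition), compound 1 gives 1790 nM, the lowest of the three numbers recorded so far. Compound 3 `COC(=O)c1cccc(Nc2ncnc3ccc(-c4cnc(OC)c(NS(=O)(=O)c5ccc(F)cc5F)c4)cc23)c1` gives 22400 nM in this assay, and compound 2 `CCS(=O)(=O)Nc1cc(-c2ccc3ncnc(Nc4ccc(OCc5ccc(F)cc5)c(Cl)c4)c3c2)cnc1OC` gives 28400 nM in this assay; both stand beyond the scatter above compound 1, compound 3 nearer and compound 2 furthest. Among the measured compounds shown here, compounds 2 and 3 each differ from compound 1 in more than one place, so no single step between measured compounds can be read from them.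

Compound 4 `CCS(=O)(=O)Nc1cc(-c2ccc3ncnc(Nc4ccc(F)nc4)c3c2)cnc1OC` has not yet been measured. It differs from compound 1 by one change only: 6-fluoropyridin-3-yl in place of 4-methoxyphenyl on a nitrogen on an aromatic ring. The rest of the shared core of compound 1 is kept. For the measured compounds named here, no measured pair isolates this change, so its size and direction remain open. Going by the values given here, the measured numbers show only that compounds 2 and 3, which carry larger groups on this nitrogen, sit far above compound 1 with its 4-methoxyphenyl. An exchange for a group of nearly the same count of heavy atoms is expected to move the number modestly, with a lean toward a somewhat higher value. Compound 4 is expected to give 3000 nM in this assay, between 800 nM and 12000 nM. The step this expectation means is a 1.7-fold higher number from compound 1 to compound 4 (0.22 log units; within the scatter), within or just beyond the scatter.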

Compound 4, half-maximal inhibitory concentration: 5390 nM
For compound 4 the middle estimate is 1.8-fold (0.25 log units) below the measured one; the range from low to high includes it.
By their numbers in this assay, from the lowest: compound 1; then compound 4; then compounds 3 and 2 (each within the scatter of the next).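

Working notes on this position. In this assay, among the compounds shown here, the exchange of 4-methoxyphenyl for 6-fluoropyridin-3-yl on a nitrogen on an aromatic ring gives a 3.0-fold higher number from compound 1 to compound 4 (0.48 log units; beyond the scatter), the first step that can be tied to this one place. Compounds 2 and 3 differ from compound 1 in more than one place, so they could not show that this position alone moves the number; compound 4 shows that it does, and that a group larger than 4-methoxyphenyl is not required for a step beyond the scatter. The hydrogen-bond donor and acceptor counts and the net charge are the same in the two groups, and no measurement shown bears on why the number rises.

The compounds shown leave open which part of the exchange carries the step: the loss of the methoxy group, the ring nitrogen or the fluorine. On these data alone, a 4-fluorophenyl or a 6-methoxypyridin-3-yl on the same nitrogen, with the rest of the core of compound 1 kept, would separate these parts, and whether any group here can give a lower number than 4-methoxyphenyl also remains open.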